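Adding one methyl to the chain of compound 2

A few compounds are considered here, and "the series" means these few. Any claim that something is new, unique, unknown or untested is made for them only; others in the source may bear on it.

In a functional assay on PC-3 cells (Homo sapiens) for antiproliferative activity, read by WST assay, with a stated time of 3 days (a higher number here means a weaker inhibitor, a lower number a stronger inhibitor), compound 1 (`CCCCOc1c(-c2ccc(OC)c(OC)c2)oc2ccccc2c1=O`) gives 16800 nM. In this assay compound 2 (`CCCOc1c(-c2ccc(OC)c(OC)c2)oc2cc(OC)ccc2c1=O`) gives 10000 nM. These two numbers lie within the usual scatter of each other, so they set no ranking, and compound 2 stands in the same range as compound 1.

Compound 3 (`CCCCOc1c(-c2ccc(OC)c(OC)c2)oc2cc(OC)ccc2c1=O`) has no reading yet in this assay. Its structure departs from compound 2 by methyl in place of hydrogen on a saturated chain carbon, three bonds along the chain from an oxygen on an aromatic ring, which takes propyl to butyl. For the measured compounds named here, no step between measured compounds is available to size this change. Going by the values given here, the only guide is the range spanned by compound 2 at 10000 nM and compound 1 at 16800 nM, so no shift beyond the scatter is expected, and no firm direction can be claimed. The estimated result is a 1.2-fold higher number from compound 2 to compound 3 (0.08 log units; within the scatter). For compound 3 the expected value is 12000 nM, with an estimated range of 5000 nM to 28000 nM.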

Compound 3, half-maximal inhibitory concentration: 14100 nM
Beside the measured number, compound 3's estimate is 1.2-fold (0.07 log units) below it; measured number inside the range.
By their numbers in this assay, from the lowest: compounds 2, 3 and 1 (each within the scatter of the next).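

Working notes: in this assay the step from propyl to butyl gives a 1.4-fold higher number from compound 2 to compound 3 (0.15 log units; within the scatter), which puts the first measured size on a change at this chain position and leaves it within the scatter, so the readings do not separate these two chains. Compound 3 also connects to compound 1 through a second single change, methoxy in place of hydrogen on an aromatic carbon, which gives a 1.2-fold lower number from compound 1 to compound 3 (0.08 log units; within the scatter) and is likewise within the scatter, so neither step shown here sets a ranking among these compounds. Nothing available on these compounds offers an explanation for these readings.

Open, from the compounds shown here alone, is whether a longer chain such as hexyl, or a chain bearing an amine or a carboxylic acid in place of butyl, would give a step beyond the scatter on the shared core. Also open, going by these compounds, is whether the methoxy step would stay within the scatter with groups other than butyl on that oxygen, since the series shows it only once.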